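Pyridin-3-yl hydrazone replacing the dimethylphenyl group

A few compounds are considered here, and "the series" means these few. Any claim that something is new, unique, unknown or untested is made for them only; others in the source may bear on it.

Measured compounds:
compound 1, `Cc1cccc(C)c1NN=C1CCC(C)n2c1ncc(C(=O)O)c2=O`, 320 umol/kg
compound 2, `Cc1cc(C)c(NN=C2CCC(C)n3c2ncc(C(=O)O)c3=O)c(C)c1`, 320 umol/kg

In a functional assay on the whole organism with Rattus norvegicus as the target (a higher number here means that more compound is needed for the effect, a lower number that less compound is needed), compound 1 gives 320 umol/kg, and compound 2 gives 320 umol/kg, so compound 1 stands level with compound 2. For the measured compounds named here, the only measured step, no change at the digits printed from compound 1 to compound 2 (within the scatter), came from a methyl in place of hydrogen on an aromatic carbon. Compound 3, `CC1CCC(=NNc2cccnc2)c2ncc(C(=O)O)c(=O)n21`, differs from compound 1 by pyridin-3-yl in place of 2,6-dimethylphenyl on an amine nitrogen. Going by the values given here, no measured step exchanges the aromatic ring itself, so the one known step bears only loosely on this change. A step of no change at the digits printed from compound 1 to compound 3 (within the scatter) is expected, none beyond the scatter, with a wide range. Compound 3 is estimated at 320 umol/kg, between 100 umol/kg and 1000 umol/kg.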

Compound 3, dose for 50% inhibition: > 320 umol/kg
Compound 3 gave a limit, no number; the forecaster's own chance of this, stated with the estimate: 15%; the middle value lies on the limit itself.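

In this assay compound 3 gives > 320 umol/kg, which is a limit of the assay and not a number. This first exchange of the aromatic ring itself, pyridin-3-yl in place of 2,6-dimethylphenyl on the amine nitrogen, gives a number no lower from compound 1 to compound 3 (the limit leaves the size open), so the size of the step cannot be read, though the exchange brought no lower dose. The result can be read only against its limit: the limit of > 320 umol/kg in this assay, at which 1 of the 3 values shown sits. Still open, going by these compounds, is how a plain phenyl or a pyridin-4-yl group would behave on the same amine nitrogen. That would help separate the part played by the ring nitrogen from that of the two methyl groups.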